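A few compounds are considered here, and "the series" means these few. Any claim that something is new, unique, unknown or untested is made for them only; others in the source may bear on it.

Measured compounds:
- compound 1, `COc1ccc(-c2cc3nccc(-c4cc(OC)c(OC)c(OC)c4)n3n2)cc1N`, in a functional assay on A549 cells (Homo sapiens) for inhibition, read by CCK-8 assay, with a stated time of 48 h (a lower number here means a stronger inhibitor, a higher number a weaker inhibitor), gives 138 nM
- compound 2, `COc1cc(-c2ccnc3cc(-c4ccc5cc[nH]c5c4)nn23)cc(OC)c1OC`, in this assay gives 170 nM

Compound 1 holds the lowest of the two numbers, but its neighbour compound 2 lies within the scatter, as the step of a 1.2-fold higher number from compound 1 to compound 2 (0.09 log units; within the scatter) shows; no order between the two can be claimed. Compound 3, `COc1cc(-c2ccnc3cc(-c4cccc(C)c4)nn23)cc(OC)c1OC`, has not yet been measured in this assay. It differs from compound 1 as follows: 3-methylphenyl in place of 3-amino-4-methoxyphenyl on an aromatic carbon. For the measured compounds named here, the only measured step that bears on this position, a 1.2-fold higher number from compound 1 to compound 2 (0.09 log units; within the scatter), also replaced the 3-amino-4-methoxyphenyl group and stayed within the scatter. A single such step does not settle whether the change to 3-methylphenyl will matter, so a step of modest size toward a higher number, a 1.8-fold higher number from compound 1 to compound 3 (0.26 log units; within the scatter), is expected. Compound 3 is therefore estimated to give 250 nM in this assay, within a range of 90 nM to 700 nM.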

Compound 3, half-maximal inhibitory concentration: 5730 nM
Beside the measured number, compound 3's estimate is 23-fold (1.36 log units) below it; the whole stated range lies below it.
By their numbers in this assay, from the lowest: compounds 1 and 2 (each within the scatter of the next); then compound 3.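

Changing the group at this aromatic carbon can matter a great deal in this assay, although the earlier exchange of 3-amino-4-methoxyphenyl for 1H-indol-6-yl stayed within the scatter. Moving to 3-methylphenyl gives a 42-fold higher number from compound 1 to compound 3 (1.62 log units; beyond the scatter) and also a 34-fold higher number from compound 2 to compound 3 (1.53 log units; beyond the scatter), so the position does not accept every substituted aromatic ring equally. Set against 3-amino-4-methoxyphenyl, the entering 3-methylphenyl has 0 hydrogen-bond donors and 0 hydrogen-bond acceptors, but nothing available here explains the rise in the number.

The three compounds do not separate the contribution of the amine from that of the methoxy group in 3-amino-4-methoxyphenyl. From the compounds shown here alone, it also remains open whether a 3-aminophenyl group, or a hydroxyl or carboxylic acid in place of the methyl group of compound 3, would bring the number back towards those of compound 1 and compound 2.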